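Notes on replacing the biaryl link with an ethyl bridge

The compounds below may be only part of what the source reports. "The series", "measured", "known", "first", "only" and "open" are said of these compounds alone.

Compound 3 `CCCCCCCCS(=O)(=O)Nc1cc(-c2ccc(O)cc2)ccc1C(=O)O` gives 64800 nM in an assay on mitochondria (strain BALB/c) for inhibition of glycerol-3-phosphate acyltransferase 1, mitochondrial (Mus musculus), read by scintillation counting, with a stated time of 10 min (a higher number here means a weaker inhibitor, a lower number a stronger inhibitor), the highest number of the three measured. Compound 2 `CCCCCCCCS(=O)(=O)Nc1cc(-c2ccccc2O)ccc1C(=O)O` gives 63100 nM, and the pair sits at a 1.0-fold higher number from compound 2 to compound 3 (0.01 log units; within the scatter). Compound 1 `CCCCCCCCS(=O)(=O)Nc1cc(-c2ccc(OC)cc2)ccc1C(=O)O` gives 13300 nM, set apart by a 4.9-fold higher number from compound 1 to compound 3 (0.69 log units; beyond the scatter) and by a 4.7-fold higher number from compound 1 to compound 2 (0.68 log units; beyond the scatter). Compound 4 `CCCCCCCCS(=O)(=O)Nc1cc(CCc2ccc(OC)cc2)ccc1C(=O)O` is not yet measured; it differs from compound 3 by 2-(4-methoxyphenyl)ethyl in place of 4-hydroxyphenyl on an aromatic carbon. Among the measured compounds shown here, of the measured steps, a 4.9-fold higher number from compound 1 to compound 3 (0.69 log units; beyond the scatter) bears most directly: it covers the methyl on the oxygen, which compound 4 restores, while the two-carbon bridge has no counterpart among the measured compounds. A step back toward the lower number is expected, about a 4.3-fold lower number from compound 3 to compound 4 (0.64 log units; beyond the scatter), with wide uncertainty from the untested bridge. Compound 4 is estimated at 15000 nM, range 4000 nM to 60000 nM.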

Compound 4, half-maximal inhibitory concentration: 43000 nM
For compound 4 the middle estimate is 2.9-fold (0.46 log units) below the measured one; the range from low to high includes it.
By their numbers in this assay, from the lowest: compound 1; then compounds 4, 2 and 3 (each within the scatter of the next).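

Swapping 4-methoxyphenyl for 2-(4-methoxyphenyl)ethyl gives a 3.2-fold higher number from compound 1 to compound 4 (0.51 log units; beyond the scatter) in this assay and so does not keep the level of compound 1, even with the methoxy group retained. The ethyl-bridged compound is not separated from either hydroxyphenyl compound, given a 1.5-fold lower number from compound 3 to compound 4 (0.18 log units; within the scatter) and a 1.5-fold lower number from compound 2 to compound 4 (0.17 log units; within the scatter) within the scatter. No available measurement explains this result.

A 2-(4-hydroxyphenyl)ethyl group would test whether the methyl on the oxygen still counts across the bridge. As far as these compounds go, how an amine in the bridge or a longer chain would read remains open.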